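The source may report more compounds than this note shows. Statements on the series, on what has been measured and on what is new or still open speak of the compounds shown alone.

Measured compounds in the series:

compound 1, `CS(=O)(=O)c1ccc(N2N=C(c3ccccc3)CCC2=O)cc1`, 47.3%
compound 2, `CS(=O)(=O)c1ccc(N2N=C(c3ccc(Br)cc3)CCC2=O)cc1`, 31.5%
compound 3, `CS(=O)(=O)c1ccc(N2N=C(c3ccc(Cl)cc3)CCC2=O)cc1`, 36.8%

All three were read in a functional assay on the whole organism (strain Wistar) for inhibition, with Rattus norvegicus as the target, read by paw edema, with stated times of 30 min and 5 h, at a dose of 0.05 mmol/kg by the oral route; a lower number here means less inhibition, a higher number more inhibition at the dose given (going by the name of the read-out). Compound 3 stands second highest of the three numbers: its nearest neighbour is compound 2, and the step of a number 5.3 percentage points higher from compound 2 to compound 3 (within the scatter) lies within the scatter, so the two are not separated; compound 1 sits above it, and the step of a number 10.5 percentage points lower from compound 1 to compound 3 (beyond the scatter) is beyond the scatter.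

The next compound is compound 4, `Cc1ccc(O)c(C2=NN(c3ccc(S(C)(=O)=O)cc3)C(=O)CC2)c1`. Its change from compound 3 is 2-hydroxy-5-methylphenyl in place of 4-chlorophenyl on a carbon with a double bond to nitrogen. The measured steps that bear on this ring are a number 15.8 percentage points lower from compound 1 to compound 2 (beyond the scatter) and a number 10.5 percentage points lower from compound 1 to compound 3 (beyond the scatter): putting a halogen onto the unsubstituted aromatic carbon lowered inhibition by a modest amount in both cases. Among the measured compounds shown here, compound 4 removes the chloro, which by the reverse of a number 10.5 percentage points lower from compound 1 to compound 3 (beyond the scatter) would argue for a modest rise back toward compound 1, but the hydroxy and methyl groups that enter have no measured counterpart. The expected step of a number 5.2 percentage points higher from compound 3 to compound 4 (within the scatter) is therefore estimated as small, within or barely beyond the scatter, upward if anything. Compound 4 is expected to give about 42%, in the range 28% to 58%.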

Compound 4, a percentage reported as inhibition, in the whole organism at one dose (the size of the read-out at that dose, not a potency): 86.8%
Compound 4: middle estimate off by 44.8 percentage points, on the low side, outside the stated range (above it).
By their numbers in this assay, from the lowest: compounds 2 and 3 (each within the scatter of the next); then compound 1; then compound 4.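

With 2-hydroxy-5-methylphenyl on the carbon with a double bond to nitrogen, this assay shows a number 50 percentage points higher from compound 3 to compound 4 (beyond the scatter), a number 55.3 percentage points higher from compound 2 to compound 4 (beyond the scatter) and a number 39.5 percentage points higher from compound 1 to compound 4 (beyond the scatter). Substitution on this aromatic ring is therefore not only a loss, as compound 2 and compound 3 alone implied, since compound 4 now stands above the unsubstituted phenyl of compound 1 and above both halogen compounds, each step beyond the scatter. No measurement at hand accounts for the size of this rise.

As far as these compounds go, the hydroxy and methyl groups enter together, so the share of each in the step remains open, and a phenyl carrying only one of them would separate the two. From the compounds shown here alone, whether a methoxy group or an amine in place of the hydroxy keeps the inhibition also remains open.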